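This account rests on a few compounds, and the source may have more. Where it says the series, first, only, none or still open, it means among the compounds named here.

Measured so far:
Compound 1 `COc1ccc(-c2nc(CNc3ccc(C(=O)NO)cc3)n(-c3ccccc3)n2)cc1`: > 20000 nM
Compound 2 `Cc1cccc(-n2nc(-c3ccccc3)nc2CNc2ccc(C(=O)NO)cc2)c1`: 13200 nM

In a functional assay on MGC-803 cells (Homo sapiens) for antiproliferative activity, read by MTT assay, with a stated time of 72 h (on this read-out higher numbers stand for weaker inhibition and lower numbers for stronger inhibition), compound 1 gives > 20000 nM, which is a limit of the assay and not a number. Compound 1 therefore sits at the limit of > 20000 nM in this assay, at which 1 of the 2 values shown sits.

Compound 3 `Cc1ccsc1-c1nc(CNc2ccc(C(=O)NO)cc2)n(-c2ccccc2)n1` has 3-methylthiophen-2-yl in place of 4-methoxyphenyl on an aromatic carbon of the core of compound 1 (3-methylthiophen-2-yl in place of 4-methoxyphenyl on an aromatic carbon). Among the compounds with values here, no measured step shows what this change does, so only a modest step towards stronger inhibition is expected in this assay, resting on compound 2 at 13200 nM as the only actual number.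

The estimated step is an at least 1.6-fold lower number from compound 1 to compound 3 (0.22 log units; that floor lies within the scatter). For compound 3 the expected value is 12000 nM, with an estimated range from 3500 nM to 20000 nM.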

Compound 3, half-maximal inhibitory concentration: 8890 nM
Beside the measured number, compound 3's estimate is 1.3-fold (0.13 log units) above it; measured number inside the range.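

In this assay, placing 3-methylthiophen-2-yl instead of 4-methoxyphenyl on this aromatic carbon gives an at least 2.2-fold lower number from compound 1 to compound 3 (0.35 log units; beyond the scatter). This first comparison at the position shows that the read-out responds to the group placed there. The step is only a floor because compound 1 stands at a limit of the assay, which is not a number: the limit of > 20000 nM in this assay, at which 1 of the 3 values shown sits.

On these data alone, whether the thiophene ring or its methyl group matters more remains open. So does the effect of an unsubstituted thiophen-2-yl or an amine at this position.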